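This account rests on a few compounds, and the source may have more. Where it says the series, first, only, none or still open, it means among the compounds named here.

Measured so far in a physicochemical assay, with a stated time of 50 min; on this read-out lower numbers stand for stronger inhibition and higher numbers for weaker inhibition:
- compound 1 `O=C(O)[C@@H]1CSC(c2cccc(Cl)c2)N1`: "nd(insoluble)" (no result reported)
- compound 2 `N#Cc1ccccc1C1N[C@H](C(=O)O)CS1`: > 1000000 nM
- compound 3 `O=C(O)[C@@H]1CSC(c2ccccc2Br)N1`: 37700 nM

The value of compound 2 is a limit of this assay, not a number. Compound 1 gave no result. For the measured compounds named here, compound 3 therefore holds the only number in this assay. Compound 4 `Cc1ccccc1C1N[C@H](C(=O)O)CS1` differs from compound 3 by methyl in place of bromo on an aromatic carbon. Going by the values given here, the one measured step at this position, an at least 26-fold lower number from compound 2 to compound 3 (1.42 log units; beyond the scatter), was large, and the limit of > 1000000 nM in this assay, at which 1 of the 3 values shown sits, marks its starting point. Among the compounds with values here, that step swapped cyano for bromo; no step swapping bromo for methyl has been measured, so only a modest change is expected here. The estimate for compound 4 is 55000 nM, within 15000 nM to 200000 nM, which means an expected step of a 1.5-fold higher number from compound 3 to compound 4 (0.16 log units; within the scatter).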

Compound 4, half-maximal inhibitory concentration: 39000 nM
Compound 4: middle estimate off by 1.4-fold (0.15 log units), on the high side; the range from low to high includes it.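

In this assay, methyl and bromo on this aromatic carbon cannot be told apart: a 1.0-fold higher number from compound 3 to compound 4 (0.01 log units; within the scatter). A second group now parts from cyano by a large step, so the gap seen with bromo is not unique to bromo: an at least 25-fold lower number from compound 2 to compound 4 (1.40 log units; beyond the scatter). The value of compound 2 is a limit, so the true size of that step stays open: the limit of > 1000000 nM in this assay, at which 1 of the 4 values shown sits.

Still open, as far as these compounds go, is how a different group at this place, such as an amine, methoxy or a carboxylic acid, would compare. Compound 1 offers no number for comparison.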